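The compounds below may be only part of what the source reports. "The series", "measured", "known", "first", "only" and "open" are said of these compounds alone.

Measured so far in a functional assay on the whole organism (Tail, strain ICR) with Mus musculus as the target, in the tail flick test, with a stated time of 60 min, at a dose of 25 umol/kg by the oral route; on this read-out higher numbers stand for a stronger effect at the one dose given and lower numbers for a weaker effect:
compound 1 `O=C(O)[C@@H]1CCCN1C(=O)CN(c1nc(Cl)nc2[nH]cnc12)C1CC1` gives 34.9%
compound 2 `N=C(N)NCCC[C@H](NC(=O)CN(c1ncnc2c1ncn2C1CCCCO1)C1CC1)C(=O)OCc1ccccc1` gives 52.4%
compound 3 `N=C(N)NCCC[C@H](NC(=O)CN(c1nc(Cl)nc2[nH]cnc12)C1CC1)C(=O)OCc1ccccc1` gives 30.6%

Compound 3 holds the lowest of the three numbers. Its reading and that of compound 1 lie within the usual scatter of each other, so nothing is made of that gap; the reading of compound 2 stands beyond the scatter.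

Compound 4 `NC(=O)C[C@H](NC(=O)CN(c1nc(Cl)nc2[nH]cnc12)C1CC1)C(=O)OCc1ccccc1` is not yet measured. It differs from compound 3 in one place: a group of 3 heavy atoms (1 carbon, 1 nitrogen, 1 oxygen; no ring) in place of a group of 6 heavy atoms (3 carbon, 3 nitrogen; no ring), on a saturated chain carbon, two bonds along the chain from an amide-type nitrogen and a carbonyl carbon. The carbamoyl group enters on a saturated chain carbon, two bonds along the chain from an amide-type nitrogen and a carbonyl carbon. Within the data shown here, no measured pair shows this change, so no step size is known; a step within the scatter, in either direction, is expected in this assay. Compound 4 is thus estimated at 28% (range 10% to 48%), a step of a number 2.6 percentage points lower from compound 3 to compound 4 (within the scatter) that is expected, not known.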

Compound 4, a percentage reported as activity, at one dose (the size of the read-out at that dose, not a potency): 36.4%
Compound 4: middle estimate off by 8.4 percentage points, on the low side; low and high end bracket the measured number.
By their numbers in this assay, from the lowest: compounds 3, 1 and 4 (each within the scatter of the next); then compound 2.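

Replacing the group of 6 heavy atoms with carbamoyl on the saturated chain carbon gives a number 5.8 percentage points higher from compound 3 to compound 4 (within the scatter) in this assay. This first step read at this position does not separate the two groups on this read-out at the one dose given. No measurement at hand bears on the reason for this result.

Open, from the compounds shown here alone, is whether an amine, a carboxylic acid or a longer chain ending in carbamoyl at this position would stand beyond the scatter from compound 4. A single dose also leaves open whether the two groups would separate at other doses.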